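The source may report more compounds than this note shows. Statements on the series, on what has been measured and on what is new or still open speak of the compounds shown alone.

Measured in a functional assay on A-375 cells (Homo sapiens) for cytotoxicity, read by MTT assay, with a stated time of 72 h, tested at 1 uM; a lower number here means less inhibition of growth, a higher number more inhibition of growth at the concentration tested:
- compound 1 `N/C(=N\NC(=S)N1CCOCC1)c1ccccn1`: 26.8%
- compound 2 `Cc1ccnc(/C(N)=N/NC(=S)N2CCOCC2)c1`: 43.2%
- compound 3 `N/C(=N\NC(=S)N1CCCC1)c1ccc(F)cn1`: 57.9%

Compound 1 stands lowest of these three numbers. Within the data shown here, the one single-point step among them, methyl in place of hydrogen on an aromatic carbon, gives a number 16.4 percentage points higher from compound 1 to compound 2 (beyond the scatter). Among the measured compounds shown here, compound 3 differs from compound 1 in two places at once, so its number shows no single step.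

Compound 4 `N/C(=N\NC(=S)N1CCCCC1)c1ccccn1` differs from compound 1 by piperidin-1-yl in place of morpholin-4-yl on a thiocarbonyl carbon. For the measured compounds named here, no measured step touches this ring, so the only measured step, a number 16.4 percentage points higher from compound 1 to compound 2 (beyond the scatter), does not bear on it directly. The expectation for compound 4 is therefore uncertain, with a small rise estimated, a number 9.2 percentage points higher from compound 1 to compound 4 (within the scatter). Compound 4 is estimated at 36%, in a range from 18% to 58%.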

Compound 4, percent growth inhibition at one concentration: 72.5%
Compound 4: the middle estimate sits 36.5 percentage points below what was measured; the whole stated range lies below it.
By their numbers in this assay, from the lowest: compound 1; then compound 2; then compound 3; then compound 4.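

In this assay, the ring on the thiocarbonyl carbon proves to be a strong lever on growth inhibition, with piperidin-1-yl in place of morpholin-4-yl giving a number 45.7 percentage points higher from compound 1 to compound 4 (beyond the scatter). The two rings have the same size and the same number of heavy atoms, and the change replaces the oxygen of morpholin-4-yl with a carbon. Nothing available explains this rise.

From the compounds shown here alone, how a piperazin-1-yl ring or an open-chain dimethylamino group would compare on the core of compound 1 remains open. So does whether the same ring change would give a similar rise on the methyl-bearing core of compound 2.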